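Anilino substituent exchange on the chloroquinazoline core

This account rests on a few compounds, and the source may have more. Where it says the series, first, only, none or still open, it means among the compounds named here.

Working notes on the series. In a functional assay on SK-HEP1 cells (Homo sapiens) for cytotoxicity, read by MTT assay, with a stated time of 48 h (on this read-out higher numbers stand for weaker inhibition and lower numbers for stronger inhibition), compound 1 `C#Cc1cccc(Nc2nc(Cl)nc3cc(OC)c(OC)cc23)c1` gives 7500 nM, the lowest of the three numbers to hand; compound 3 `COc1cc2nc(Cl)nc(Nc3ccc(Cl)c(C(F)(F)F)c3)c2cc1OC` gives 8800 nM and compound 2 `C#Cc1cccc(N(C)c2nc(Cl)nc3cc(OC)c(OC)cc23)c1` gives 12300 nM, both within the scatter of compound 1. Among the measured compounds shown here, the only single-point step known, a 1.6-fold higher number from compound 1 to compound 2 (0.21 log units; within the scatter), concerns the nitrogen on the shared core and does not touch the aniline substituent itself. Compound 4 `COc1cc2nc(Cl)nc(Nc3cccc(Oc4ccc(C#N)cc4)c3)c2cc1OC` carries 4-cyanophenoxy in place of ethynyl on an aromatic carbon. For the measured compounds named here, no measured step bears directly on this exchange; the values of compound 1 and compound 3 merely show that a different substituent pattern on the aniline left the number within scatter. A step of no more than the scatter in either direction is therefore expected, a 1.2-fold higher number from compound 1 to compound 4 (0.08 log units; within the scatter). Compound 4 is estimated at 9000 nM, range 3000 nM to 30000 nM.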

Compound 4, half-maximal inhibitory concentration: > 40000 nM
Compound 4 ended at the assay's limit (the forecaster's own chance of this, stated with the estimate: 10%); at least 4.4-fold (0.64 log units) between middle value and limit.
By their numbers in this assay, from the lowest: compounds 1, 3 and 2 (each within the scatter of the next). At a limit, above all of these: compound 4.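

In this assay, among the compounds shown here, 4-cyanophenoxy in place of ethynyl on an aromatic carbon gives the first step at this position that lies beyond the scatter: an at least 5.3-fold higher number from compound 1 to compound 4 (0.72 log units; beyond the scatter). The value of compound 4, > 40000 nM, is a limit of the assay. This exchange therefore does not leave the number within the scatter, and the reading rests on that single value: the limit of > 40000 nM in this assay, at which 1 of the 4 values shown sits.

Which part of 4-cyanophenoxy carries the step, the ether oxygen, the ring or the nitrile, remains open. Going by these compounds, how a plain phenoxy, a methoxy or an amine would read on the same carbon also remains open.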